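From 3-chlorophenyl to 4-cyanophenyl on the shared core

The compounds below may be only part of what the source reports. "The series", "measured", "known", "first", "only" and "open" are said of these compounds alone.

In a functional assay on MDA-MB-231 cells (Homo sapiens) for antiproliferative activity, read by CCK-8 assay, with a stated time of 72 h (on this read-out higher numbers stand for weaker inhibition and lower numbers for stronger inhibition), compound 3 `Cc1cc(Nc2cc(N3CCN(C)CC3)nc(Nc3cccc(Cl)c3)n2)n[nH]1` gives 56.4 nM, within the scatter of compound 1 `Cc1cc(Nc2cc(N3CCN(C)CC3)nc(Nc3ccc([N+](=O)[O-])cc3)n2)n[nH]1` at 84.4 nM, while compound 2 `COc1cccc(Nc2nc(Nc3cc(C)[nH]n3)cc(N3CCN(C)CC3)n2)c1` stands apart at 240 nM. Compound 4 `Cc1cc(Nc2cc(N3CCN(C)CC3)nc(Nc3ccc(C#N)cc3)n2)n[nH]1` carries 4-cyanophenyl in place of 3-chlorophenyl on a nitrogen on an aromatic ring. Within the data shown here, the closest precedent is the exchange of 4-nitrophenyl for 3-chlorophenyl, the step of a 1.5-fold lower number from compound 1 to compound 3 (0.18 log units; within the scatter), which stayed within the scatter. Among the measured compounds shown here, only the steps involving the 3-methoxyphenyl group, a 2.8-fold higher number from compound 1 to compound 2 (0.45 log units; beyond the scatter) and a 4.3-fold lower number from compound 2 to compound 3 (0.63 log units; beyond the scatter), went beyond it, and both were modest. No step beyond the scatter is therefore expected, and the estimated change is a 1.5-fold higher number from compound 3 to compound 4 (0.18 log units; within the scatter). In this assay the expected value for compound 4 is 85 nM, with an estimated range from 35 nM to 210 nM.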

Compound 4, half-maximal inhibitory concentration: 75.7 nM
For compound 4 the middle estimate is 1.1-fold (0.05 log units) above the measured one; measured number inside the range.
By their numbers in this assay, from the lowest: compounds 3, 4 and 1 (each within the scatter of the next); then compound 2.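

On a nitrogen on an aromatic ring, 4-cyanophenyl in place of 3-chlorophenyl stays within the scatter in this assay (a 1.3-fold higher number from compound 3 to compound 4 (0.13 log units; within the scatter)), and so does cyano in place of nitro (a 1.1-fold lower number from compound 1 to compound 4 (0.05 log units; within the scatter)). The step from the 3-methoxyphenyl compound is beyond the scatter but modest (a 3.2-fold lower number from compound 2 to compound 4 (0.50 log units; beyond the scatter)). Among these four compounds, the nitrile thus groups with the chloro and nitro compounds, and only compound 2 stands apart. No measurement shown accounts for this grouping. From the compounds shown here alone, whether a phenyl carrying a carboxylic acid or an amine would stay in that group remains open.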